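Chloro to Cyano on a Cytotoxicity Read-Out

This account rests on a few compounds, and the source may have more. Where it says the series, first, only, none or still open, it means among the compounds named here.

Measured compounds:
compound 1, `CCS(=O)(=O)Nc1ccc(NC(=O)c2ccc(Cl)cc2)cc1Cl`, > 250000 nM
compound 2, `CCS(=O)(=O)Nc1ccc(NC(=O)c2ccc(C#N)cc2)cc1Cl`, > 250000 nM
compound 3, `O=C(Nc1ccc(NS(=O)(=O)C(F)(F)F)c(F)c1)c1ccc(Cl)cc1`, 79000 nM

In an ADME assay on HEK293 cells (Homo sapiens) for cytotoxicity, read by MTT assay, with a stated time of 48 h (on this read-out higher numbers stand for weaker inhibition and lower numbers for stronger inhibition), compound 1 gives > 250000 nM, which is a limit of the assay rather than a number. In this assay compound 2 likewise gives > 250000 nM, again a limit. Compound 2 differs from compound 1 by cyano in place of chloro on an aromatic carbon, and the step that the two limits leave unreadable from compound 1 to compound 2 cannot be read because of the limit of > 250000 nM in this assay, at which 2 of the 3 values shown sit. Compound 3 differs from compound 1 in more than one place; the difference between the two cores is not broken down here. In this assay, among the compounds with values here, compound 3 gives 79000 nM, the only plain number among the three.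

Compound 4, `N#Cc1ccc(C(=O)Nc2ccc(NS(=O)(=O)C(F)(F)F)c(F)c2)cc1`, has not yet been measured in this assay. Within the data shown here, it differs from compound 3 by cyano in place of chloro on an aromatic carbon, the same change as the one from compound 1 to compound 2. For compound 4 the step of a 1.3-fold higher number from compound 3 to compound 4 (0.10 log units; within the scatter) is expected to stay within the usual scatter, resting on the value of compound 3, 79000 nM, since the earlier step gave no readable size. Compound 4 is therefore estimated at 100000 nM, between 40000 nM and 250000 nM.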

Compound 4, half-maximal inhibitory concentration: > 250000 nM
Compound 4 gave a limit, no number; the forecaster's own chance of this, stated with the estimate: 30%; at least 2.5-fold (0.39 log units) between middle value and limit.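

On the core of compound 3, cyano in place of chloro gives an at least 3.1-fold higher number from compound 3 to compound 4 (0.50 log units; beyond the scatter) in this assay. From the compounds shown here alone, compound 4 gives > 250000 nM, which is a limit of this assay and not a number, so the true size of this step stays unknown and only its lower bound can be read. The same change on the core of compound 1 cannot be read, so the direction seen on the core of compound 3 finds nothing against it there, but there is also no proof that the change carries over from one core to the other, or that its size would match: the limit of > 250000 nM in this assay, at which 3 of the 4 values shown sit.

Going by these compounds, whether an amine or a carboxylic acid on the same aromatic carbon, in place of chloro or cyano, would give a plain number in this assay stays open. Also open is which of the places where compound 1 and compound 3 differ matters, since a pair changing only the ethyl chain for trifluoromethyl is not among those shown.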